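The compounds below may be only part of what the source reports. "The series", "measured", "known", "first", "only" and "open" are said of these compounds alone.

Working notes on the series. In an ADME assay on HepG2 cells (Homo sapiens) for cytotoxicity, read by neutral red uptake, with a stated time of 24 h (on this read-out lower numbers stand for stronger inhibition and higher numbers for weaker inhibition), compound 1 (`CC(=O)Oc1c(C(C)C)cc2c3c1OC(=O)[C@@]31CCCC(C)(C)[C@@H]1CC2`) reads 294000 nM and compound 2 (`CC(C)C(=O)Oc1c(C(C)C)cc2c3c1OC(=O)[C@@]31CCCC(C)(C)[C@@H]1CC2`) reads 112000 nM while compound 3 (`CCC(=O)Oc1c(C(C)C)cc2c3c1OC(=O)[C@@]31CCCC(C)(C)[C@@H]1CC2`) reads 196000 nM on the same core. The steps of a 1.5-fold lower number from compound 1 to compound 3 (0.18 log units; within the scatter) and a 1.8-fold higher number from compound 2 to compound 3 (0.24 log units; within the scatter) leave compound 3 unseparated from either of the other two. For the measured compounds named here, only the step of a 2.6-fold lower number from compound 1 to compound 2 (0.42 log units; beyond the scatter) clears the scatter, and it is modest.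

Compound 4 (`CCCCCCCCCCCC(=O)Oc1c(C(C)C)cc2c3c1OC(=O)[C@@]31CCCC(C)(C)[C@@H]1CC2`) carries nonyl in place of hydrogen on a saturated chain carbon, two bonds along the chain from a carbonyl carbon. Going by the values given here, no measured step adds a chain of that length, so the three compounds bear on this change only indirectly. Among the compounds with values here, the expectation rests mainly on the single step beyond the scatter, with compound 2 as its only support, and it is a long extrapolation. In this assay a modest move toward a lower number is expected, of about the size seen from compound 1 to compound 2, with wide uncertainty in both directions. The expected step is a 2.0-fold lower number from compound 3 to compound 4 (0.29 log units; within the scatter) and it remains an estimate. Compound 4 is estimated at 100000 nM (expected range 35000 nM to 300000 nM).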

Compound 4, half-maximal inhibitory concentration: > 1000000 nM
Compound 4 gave a limit, no number; the forecaster's own chance of this, stated with the estimate: 15%; at least 10-fold (1.00 log units) between middle value and limit.
By their numbers in this assay, from the lowest: compounds 2, 3 and 1 (each within the scatter of the next, the first and the last beyond it). At a limit, above all of these: compound 4.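

The reading for compound 4 in this assay is a limit of the assay and not a number, so every step to it gives only a minimum size: the limit of > 1000000 nM in this assay, at which 1 of the 4 values shown sits.

For the compounds shown here, on a saturated chain carbon, two bonds along the chain from a carbonyl carbon, nonyl in place of hydrogen gives an at least 5.1-fold higher number from compound 3 to compound 4 (0.70 log units; beyond the scatter), which clears the scatter and runs opposite to the one step beyond the scatter among the earlier compounds. The same separation holds against the other two compounds, with an at least 8.9-fold higher number from compound 2 to compound 4 (0.95 log units; beyond the scatter) and an at least 3.4-fold higher number from compound 1 to compound 4 (0.53 log units; beyond the scatter), so the lower number seen with isopropyl on the carbonyl carbon does not carry over to undecyl there.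

The compounds shown leave open how far the true number of compound 4 lies past its limit, and where the number starts to rise on going from isopropyl to undecyl on the carbonyl carbon, for instance with hexyl. Also open, as far as these compounds go, is whether a chain carrying an amine or a carboxylic acid in place of undecyl would return a readable number in this assay.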